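Swapping the ester group on a shared quinolinone core

The source may report more compounds than this note shows. Statements on the series, on what has been measured and on what is new or still open speak of the compounds shown alone.

Three compounds sharing one core were tested in an ADME assay on HepG2 2.2.15 cells (Homo sapiens) for cytotoxicity; on this read-out lower numbers stand for higher toxicity in this test and higher numbers for lower toxicity in this test. Compound 1 `O=C(O)CCCC(=O)OCCc1c(-c2ccccc2Cl)c2cc(Cl)ccc2[nH]c1=O` gives 110000 nM; compound 2 `O=C(OCCc1c(-c2ccccc2Cl)c2cc(Cl)ccc2[nH]c1=O)c1ccccc1` gives 43000 nM; compound 3 `O=C(COc1ccccc1)OCCc1c(-c2ccccc2Cl)c2cc(Cl)ccc2[nH]c1=O` gives 81000 nM. Compound 3 stands second highest of the three numbers; its gap to compound 1 and its gap to compound 2 both lie within the usual scatter, so the three values cannot be ordered with confidence.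

Compound 4 `O=C(/C=C/c1cccnc1)OCCc1c(-c2ccccc2Cl)c2cc(Cl)ccc2[nH]c1=O` is not yet measured. It differs from compound 3 in one place: 2-(pyridin-3-yl)ethenyl in place of phenoxymethyl on a carbonyl carbon. Two earlier steps changed the group on the same carbonyl carbon. Going from compound 1 to compound 2 gave a 2.6-fold lower number from compound 1 to compound 2 (0.41 log units; beyond the scatter), and going from compound 2 to compound 3 gave a 1.9-fold higher number from compound 2 to compound 3 (0.28 log units; within the scatter). Exchanges at this position have therefore moved the number at most modestly, and in no consistent direction. The new group again replaces one aromatic substituent with another, with a nitrogen in place of an oxygen as acceptor. For compound 4 the expected step is a 1.2-fold lower number from compound 3 to compound 4 (0.06 log units; within the scatter), most likely no change beyond the scatter. Compound 4 is thus estimated at 70000 nM, with a range from 30000 nM to 160000 nM.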

Compound 4, half-maximal cytotoxic concentration: 39000 nM
For compound 4 the middle estimate is 1.8-fold (0.25 log units) above the measured one, within the range that was stated.
By their numbers in this assay, from the lowest: compounds 4, 2, 3 and 1 (each within the scatter of the next, the first and the last beyond it).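

Going by these compounds alone, at this carbonyl carbon, a 2.1-fold lower number from compound 3 to compound 4 (0.32 log units; beyond the scatter) in this assay is the only step between two aromatic substituents so far that lies beyond the scatter, although it is modest. The two groups exchanged match in heavy-atom count, with one six-membered aromatic ring and one hydrogen-bond acceptor each, so these counts alone do not set the number; the exchange also brings in a ring nitrogen and a double bond outside the ring. The other two steps place compound 4 with compound 2 rather than with compound 1, as a 1.1-fold lower number from compound 2 to compound 4 (0.04 log units; within the scatter) stays within the scatter while a 2.8-fold lower number from compound 1 to compound 4 (0.45 log units; beyond the scatter) goes beyond it, so both compound 2 and compound 4 lie clearly apart from compound 1, whereas compound 3 does not.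

No measurement at hand accounts for the step from compound 3 to compound 4. The compounds shown do not separate the part played by the ring nitrogen from that of the double bond, which a plain 2-phenylethenyl group could do, and they leave open how an amine on this carbonyl carbon would read.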